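Swapping the Aminoethylamine Arm for an Indole Ring

A few compounds are considered here, and "the series" means these few. Any claim that something is new, unique, unknown or untested is made for them only; others in the source may bear on it.

Compound 1 `NCCNc1cc(/C=C/c2ccccc2)nc2ccccc12` carries a (2-aminoethyl)amino arm on its core. Going by the values given here, in an ADME assay on J774 cells (Mus musculus) for cytotoxicity, read by MTT assay, with a stated time of 48 h (a higher number here means a weaker inhibitor, a lower number a stronger inhibitor), compound 1 gives 4600 nM, the lowest of the three numbers measured so far. Compound 2 `CCOCC(=O)NCCNc1cc(/C=C/c2ccccc2)nc2ccccc12` gives 22200 nM, and compound 3 `CCOCC(=O)NCCCCNc1cc(/C=C/c2ccccc2)nc2ccccc12` gives 7200 nM. The step of a 4.8-fold higher number from compound 1 to compound 2 (0.68 log units; beyond the scatter) shows that capping the arm shifts the number beyond the scatter, while a 1.6-fold higher number from compound 1 to compound 3 (0.19 log units; within the scatter) stays within it, and a 3.1-fold lower number from compound 2 to compound 3 (0.49 log units; beyond the scatter) moves back down.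

Compound 4 `C(=C/c1cc(-c2c[nH]c3ccccc23)c2ccccc2n1)\c1ccccc1` differs from compound 1 by 1H-indol-3-yl in place of (2-aminoethyl)amino on an aromatic carbon. Among the compounds with values here, no measured step bears directly on this: all three steps so far alter the chain rather than replace it with a ring. The measured steps only show that changes at this position move this assay by modest amounts, so a modest shift is expected here too, with the direction uncertain; the estimate is centred slightly below compound 1, giving a 1.5-fold lower number from compound 1 to compound 4 (0.19 log units; within the scatter). Compound 4 is therefore expected to give 3000 nM, within a range of 800 nM to 12000 nM.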

Compound 4, half-maximal inhibitory concentration: 4100 nM
Compound 4: middle estimate off by 1.4-fold (0.14 log units), on the low side; low and high end bracket the measured number.
By their numbers in this assay, from the lowest: compounds 4, 1 and 3 (each within the scatter of the next); then compound 2.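

Replacing the open (2-aminoethyl)amino arm with the two-ring 1H-indol-3-yl group gives a 1.1-fold lower number from compound 1 to compound 4 (0.05 log units; within the scatter) in this assay. The earlier steps shown here only altered the chain, whereas this one removes the arm and its terminal amine altogether, so in this assay the position accepts a change from chain to ring with no shift beyond the scatter. Nothing available explains why two such different groups give numbers within the scatter of each other.

From the compounds shown here alone, it remains open whether a simpler ring at this position, such as phenyl or pyridine, would also stay within the scatter of compound 1. The same question applies to a methyl group on the indole nitrogen of compound 4, or to a longer chain ending in a carboxylic acid.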